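The source may hold more compounds than are shown below. What is called first, only, known or untested is meant among the compounds shown, and "the series" means these compounds.

In an ADME assay on CCRF-CEM cells (Homo sapiens) for cytotoxicity, with a stated time of 5 days (a higher number here means that more compound is tolerated, a lower number that less compound is tolerated), compound 1 (`Cc1nc(N)nc2c1ncn2[C@@H]1O[C@H](CO)[C@@H](O)[C@@]1(C)O`) gives 13000 nM as a real measured number. Compound 2 (`COc1nc(Cl)nc2c1ncn2[C@@H]1O[C@H](CO)[C@@H](O)[C@@]1(C)O`) gives > 100000 nM which is a limit of the assay and not a number. Compound 3 (`C[C@@]1(O)[C@H](O)[C@@H](CO)O[C@H]1n1cnc2c(N)nc(NN)nc21`) gives > 100000 nM and this too is only a limit. Compound 3 therefore stands at the tolerated end of the scale, at the limit of > 100000 nM in this assay, at which 2 of the 3 values shown sit, with no exact value known.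

Compound 4 (`C[C@@]1(O)[C@H](O)[C@@H](CO)O[C@H]1n1cnc2c(N)nc(-n3cc([Si](C)(C)C)nn3)nc21`) differs from compound 3 in one place, an aromatic carbon between two ring nitrogen atoms. The change there is a group of 9 heavy atoms (5 carbon, 3 nitrogen, 1 silicon; one five-membered aromatic ring with 3 hetero atoms) in place of a group of 2 heavy atoms (2 nitrogen; no ring), on an aromatic carbon and it swaps a small open group for a larger one that holds a ring. For the measured compounds named here, no measured pair shows what such a swap does. Compound 1 at 13000 nM shows that a number can be reached in this family, so some movement towards less tolerated is possible. The expected step is an at least 1.4-fold lower number from compound 3 to compound 4 (0.15 log units; that floor lies within the scatter) and it may not clear the scatter at all. For compound 4 the estimate is 70000 nM with an expected range from 20000 nM to 150000 nM and a fair chance of another limit.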

Compound 4, half-maximal cytotoxic concentration: > 100000 nM
Compound 4 was reported as a limit; the forecaster's own chance of this, stated with the estimate: 60%; middle value at least 1.4-fold (0.15 log units) from the limit.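

Compound 3 and compound 4 both end at a limit of the assay and not at a number, so no step can be read between them: the limit of > 100000 nM in this assay, at which 3 of the 4 values shown sit. The compounds shown leave open the exact values of both compounds in this assay and whether the swap to the larger group that holds a ring changes anything there.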